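Chloro at the para position of the bromoacrylamide series

The source may report more compounds than this note shows. Statements on the series, on what has been measured and on what is new or still open speak of the compounds shown alone.

Measured so far in a functional assay on FM3A cells (Mus musculus) for inhibition, read by cell counting, with a stated time of 2 days; a higher number here means a weaker inhibitor, a lower number a stronger inhibitor:
compound 1, `Nc1cccc(-c2cn3c(-c4ccc(Cl)cc4)csc3n2)c1`, gives 11000 nM;
compound 2, `C=C(Br)C(=O)Nc1cccc(-c2cn3c(-c4ccccc4)csc3n2)c1`, gives 1300 nM.

Compound 2 shows the lower of the two numbers in this assay, and compound 1 the higher. Within the data shown here, the two compounds differ in more than one place, so no single step between them can be read.

Compound 3, `C=C(Br)C(=O)Nc1cccc(-c2cn3c(-c4ccc(Cl)cc4)csc3n2)c1`, is compound 2 with chloro in place of hydrogen on an aromatic carbon. Among the measured compounds shown here, no measured pair isolates this change. The step from compound 2 to compound 3 is expected to be a 1.2-fold lower number from compound 2 to compound 3 (0.07 log units; within the scatter), not clearly beyond the scatter in either direction. Compound 3 is therefore estimated at 1100 nM, with a range from 350 nM to 3500 nM.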

Compound 3, half-maximal inhibitory concentration: 1100 nM
The estimate for compound 3 equals the measured number at the digits printed; the measured number falls inside the stated range.
By their numbers in this assay, from the lowest: compounds 3 and 2 (each within the scatter of the next); then compound 1.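

In this assay the change from phenyl to 4-chlorophenyl gives a 1.2-fold lower number from compound 2 to compound 3 (0.07 log units; within the scatter) and so leaves the number within the scatter at this place, para to a large group. With chloro held fixed, the gain from (1-bromoethenyl)carbonyl on the nitrogen can now be read alone as a 10-fold lower number from compound 1 to compound 3 (1.00 log units; beyond the scatter) in the same assay. No evidence on the cause of either step is available.

Open, on these data alone, is whether a methoxy group or an amine at the same position would also stay within the scatter. Also open, as far as these compounds go, is whether an acetyl group on the nitrogen would give a step of similar size.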